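Hydroxyphenyl isomer series: no inhibition recorded so far

The compounds below may be only part of what the source reports. "The series", "measured", "known", "first", "only" and "open" are said of these compounds alone.

Measured compounds:
compound 1, `Oc1ccc(-c2cc(-c3ccccc3O)cc(-c3ccccc3O)n2)cc1` — 0.3%
compound 2, `Oc1cccc(-c2cc(-c3ccccc3O)cc(-c3cccc(O)c3)n2)c1` — 0%
compound 3, `Oc1ccc(-c2cc(-c3ccc(O)cc3)nc(-c3cccc(O)c3)c2)cc1` — 0%

All three values come from an assay on isolated protein for inhibition of DNA topoisomerase 1 (Homo sapiens), with a stated time of 30 min, tested at 100 uM; a higher number here means more inhibition at the concentration tested (going by the name of the read-out), a lower number less inhibition. In this assay compound 1 gives 0.3%, compound 2 gives 0% and compound 3 gives 0%. Compound 3 stands level with compound 2 at the digits shown, and the two together hold the lowest numbers of the three; the nearest neighbour is compound 2, with no change at the digits shown, and the furthest is compound 1, whose number is higher by a margin that still falls within the scatter. None of the three is separated from another beyond the scatter, so no order among them can be read from this assay.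

The next compound, compound 4, `Oc1ccc(-c2cc(-c3ccccc3O)cc(-c3cccc(O)c3)n2)cc1`, is a further rearrangement of the same atoms. It differs from compound 3 as follows: 2-hydroxyphenyl in place of 4-hydroxyphenyl on an aromatic carbon. For the measured compounds named here, no step between measured compounds is available to guide the expectation. Since compounds 1, 2 and 3 all sit together within the scatter at essentially no inhibition, the step from compound 3 to compound 4 is expected to be none beyond the scatter, a number 0.5 percentage points higher from compound 3 to compound 4 (within the scatter). Compound 4 is therefore estimated at 0.5% in this assay, with a range from 0% to 8%.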

Compound 4, a percentage reported as inhibition, at one concentration (the size of the read-out at that concentration, not a potency): 0%
For compound 4 the middle estimate is 0.5 percentage points above the measured one, and the stated range covers the measured number.
By their numbers in this assay, from the lowest: compounds 2, 3, 4 and 1 (each within the scatter of the next).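

Placing 2-hydroxyphenyl in place of 4-hydroxyphenyl on the aromatic carbon opposite the ring nitrogen gives the series its first one-place comparison in this assay, and the outcome is no change at the digits printed from compound 3 to compound 4 (within the scatter). The two other one-place swaps read the same way: 4-hydroxyphenyl in place of 3-hydroxyphenyl gives no change at the digits printed from compound 2 to compound 4 (within the scatter), and 3-hydroxyphenyl in place of 2-hydroxyphenyl gives a number 0.3 percentage points lower from compound 1 to compound 4 (within the scatter), so none of these three rearrangements of the same atoms separates one compound from another in this assay. No independent measurement bears on this result.

With all four compounds sitting together within the scatter, the shown data cannot say whether the placement of the hydroxyl group matters at all for this read-out, since no compound gives a number from which a loss could be seen. Also open, as far as these compounds go, is whether the position opposite the ring nitrogen responds to anything other than a hydroxyphenyl, for instance a phenyl ring carrying an amine or a carboxylic acid, or a longer chain in its place.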